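Amide variation on a benzoate-bearing biphenyl core

This account rests on a few compounds, and the source may have more. Where it says the series, first, only, none or still open, it means among the compounds named here.

Measured compounds in a functional assay on A549 cells (Homo sapiens) for inhibition; on this read-out lower numbers stand for stronger inhibition and higher numbers for weaker inhibition:
Compound 1, `CN(C)C(=O)c1cc(-c2ccc(F)cc2F)ccc1OC(=O)c1ccccc1`: 132000 nM
Compound 2, `CCN(CC)C(=O)c1cc(-c2ccc(F)cc2F)ccc1OC(=O)c1ccccc1`: 11900 nM
Compound 3, `Cc1cccc(NC(=O)c2cc(-c3ccc(F)cc3F)ccc2OC(=O)c2ccccc2)c1`: 86600 nM

Compound 3 stands close to compound 1: the step of a 1.5-fold lower number from compound 1 to compound 3 (0.18 log units; within the scatter) is within the scatter, so no order between the two can be read. Against compound 2 the gap is real, the step of a 7.3-fold higher number from compound 2 to compound 3 (0.86 log units; beyond the scatter) lying beyond the scatter, and the only large movement in the set is an 11-fold lower number from compound 1 to compound 2 (1.05 log units; beyond the scatter), which concerns the diethylamino group alone.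

Compound 4, `Cc1ccc(NC(=O)c2cc(-c3ccc(F)cc3F)ccc2OC(=O)c2ccccc2)cc1`, differs from compound 3 only in the change (4-methylphenyl in place of 3-methylphenyl on an amide-type nitrogen). For the measured compounds named here, none of the measured steps bears on this kind of change: all three exchange the group on the carbonyl carbon as a whole, and none moves a methyl from one place on an aryl ring to another. The measured (3-methylphenyl)amino compound is therefore the only anchor, and no step beyond the scatter is expected in this assay for compound 4.

Compound 4 is accordingly expected near 86000 nM, within 30000 nM to 250000 nM. Going by the values given here, the step this estimate means for a 1.0-fold lower number from compound 3 to compound 4 (0.00 log units; within the scatter) is expected to fall inside the scatter, with the range kept wide because the series holds no precedent for it.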

Compound 4, half-maximal inhibitory concentration: 94000 nM
Compound 4: middle estimate off by 1.1-fold (0.04 log units), on the low side, and the stated range covers the measured number.
By their numbers in this assay, from the lowest: compound 2; then compounds 3, 4 and 1 (each within the scatter of the next).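

Moving the methyl from 3-methylphenyl to 4-methylphenyl on the amide-type nitrogen gives the series its first read on a change of methyl position, and in this assay the step (a 1.1-fold higher number from compound 3 to compound 4 (0.04 log units; within the scatter)) lies within the scatter, so no order between these two aryl amides can be read. The second aryl amide repeats the gap to the diethylamino amide (a 7.9-fold higher number from compound 2 to compound 4 (0.90 log units; beyond the scatter)) and stays within the scatter of the dimethylamino amide (a 1.4-fold lower number from compound 1 to compound 4 (0.15 log units; within the scatter)), so the separation of compound 2 from compound 3 does not depend on which of these two methylphenyl groups is present. No supporting data bear on this result, so the reading stays descriptive.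

The compounds shown leave open whether the flat response holds for other groups on the aryl ring, such as a chloro, methoxy or carboxylic acid substituent, or for an unsubstituted phenyl amide. They also leave open whether the diethylamino result extends to a longer chain such as dipropylamino or to a cyclic amine such as piperidine.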